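A few compounds are considered here, and "the series" means these few. Any claim that something is new, unique, unknown or untested is made for them only; others in the source may bear on it.

The measured compounds:

compound 1, `Nc1ncnc2c1ncn2[C@@H]1O[C@H](CSCCCC(=O)O)[C@@H](O)[C@H]1O`, with no result reported in an assay for inhibition of tRNA (cytosine(38)-C(5))-methyltransferase (Homo sapiens), with a stated time of 5 min, tested at 100 uM; on this read-out higher numbers stand for more inhibition at the one concentration tested (going by the name of the read-out) and lower numbers for less inhibition
compound 2, `Nc1ncnc2c1ncn2[C@@H]1O[C@H](CN(CC[C@H](N)C(=O)O)CC2CC2)[C@@H](O)[C@H]1O`, 27.5%
compound 3, `C=CCN(CC[C@H](N)C(=O)O)C[C@H]1O[C@@H](n2cnc3c(N)ncnc32)[C@H](O)[C@@H]1O`, 53.9%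

Compound 2 holds the lowest of the two numbers in this assay; its nearest neighbour is compound 3, and the step of a number 26.4 percentage points higher from compound 2 to compound 3 (beyond the scatter) lies beyond the scatter and is modest in size. Compound 1 gives no single number to compare against.

Compound 4, `Nc1ncnc2c1ncn2[C@@H]1O[C@H](CN(CC[C@H](N)C(=O)O)Cc2ccccc2)[C@@H](O)[C@H]1O`, is not yet measured. It differs from compound 2 by phenyl in place of cyclopropyl on a saturated chain carbon bound to an amine nitrogen.

Among the compounds with values here, only one measured step bears on this change: the step from compound 2 to compound 3, where vinyl replaces cyclopropyl on the same saturated chain carbon bound to the amine nitrogen, with the modest rise a number 26.4 percentage points higher from compound 2 to compound 3 (beyond the scatter). Phenyl is a different group from vinyl, so that step is only a loose guide. The expectation is therefore a small rise, or no change beyond the scatter, a number 12.5 percentage points higher from compound 2 to compound 4 (beyond the scatter). Compound 4 is estimated to give 40%, within the range 15% to 65%.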

Compound 4, a percentage reported as inhibition, at one concentration (the size of the read-out at that concentration, not a potency): 56.8%
The estimate for compound 4 lay 16.8 percentage points below the measured number; the range from low to high includes it.
By their numbers in this assay, from the lowest: compound 2; then compounds 3 and 4 (each within the scatter of the next).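

In this assay, phenyl in place of cyclopropyl on a saturated chain carbon bound to an amine nitrogen gives a number 29.3 percentage points higher from compound 2 to compound 4 (beyond the scatter), so the rise seen earlier with vinyl is not confined to that group and also appears with a six-membered aromatic ring. Phenyl in place of vinyl gives a number 2.9 percentage points higher from compound 3 to compound 4 (within the scatter), so these two groups cannot be told apart here, and among the three compounds with numbers, cyclopropyl alone stands apart. Nothing available explains why cyclopropyl differs from the other two groups.

The compounds shown do not tell whether a phenyl ring carrying a carboxylic acid or an amine would keep this level of inhibition. They also leave open whether a longer chain between the amine nitrogen and the phenyl ring would raise, lower or preserve it.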